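Extending the Sulfonyl Group in a Pendrin Inhibitor Series

The source may report more compounds than this note shows. Statements on the series, on what has been measured and on what is new or still open speak of the compounds shown alone.

The measured compounds:
Compound 1, `Cn1nc(COc2cc(F)cc(F)c2)c2c1CCN(C(=O)Nc1ccc(Cl)cc1)C2`, gives 3100 nM in an assay on cells for inhibition of Pendrin (Mus musculus), read by fluorescence, with a stated time of 10 min; on this read-out lower numbers stand for stronger inhibition and higher numbers for weaker inhibition.
Compound 2, `CC(C)NC(=O)N1CCc2c(c(COc3cc(F)cc(F)c3)nn2C)C1`, gives a limit of > 10000 nM in this assay.
Compound 3, `Cn1nc(COc2cc(F)cc(F)c2)c2c1CCN(S(C)(=O)=O)C2`, gives a limit of > 10000 nM in this assay.

Compound 3 stands at the limit of this assay and shares that position with compound 2, as the limit of > 10000 nM in this assay, at which 2 of the 3 values shown sit, records; only compound 1 returns a number. The step of an at least 3.2-fold higher number from compound 1 to compound 3 (0.50 log units; beyond the scatter) and the step of an at least 3.2-fold higher number from compound 1 to compound 2 (0.50 log units; beyond the scatter) are both beyond the scatter, whereas the step that the two limits leave unreadable from compound 2 to compound 3 cannot be read from two limits.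

Compound 4, `CCN(CC)S(=O)(=O)N1CCc2c(c(COc3cc(F)cc(F)c3)nn2C)C1`, differs from compound 3 by diethylamino in place of methyl on a sulfonyl sulfur. Within the data shown here, none of the measured steps touches the substituent on the sulfonyl sulfur; they all concern exchanges on the ring nitrogen itself. Among the measured compounds shown here, with no measured step bearing on this change, the expectation for compound 4 in this assay is a step of a number no higher from compound 3 to compound 4 (the limit leaves the size open), which is to say no change that can be told from a limit. The estimate for compound 4 is therefore 10000 nM, with a range from 3000 nM to 30000 nM, and it is expected most likely to remain a limit.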

Compound 4, half-maximal inhibitory concentration: > 10000 nM
Compound 4 gave a limit, no number; the forecaster's own chance of this, stated with the estimate: 70%; the middle value lies on the limit itself.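

Diethylamino on the sulfonyl sulfur, like methyl, gives no number in this assay, so neither sulfonyl group shown on the ring nitrogen has a measurable value. Against the (4-chlorophenyl)carbamoyl group, diethylsulfamoyl gives an at least 3.2-fold higher number from compound 1 to compound 4 (0.50 log units; beyond the scatter), which extends the gap already seen with the other two replacements. The steps among compound 2, compound 3 and compound 4 cannot be read, so the exchange of methyl for diethylamino has no readable size, and most of the set now rests on a single reading: the limit of > 10000 nM in this assay, at which 3 of the 4 values shown sit.

On these data alone, it remains open whether any group on the sulfonyl sulfur can return a number in this assay. A 4-chlorophenyl group on that sulfur, or a cyclic amine such as morpholine, would test this, and the former would also show whether the 4-chlorophenyl group of compound 1 keeps its value without the urea.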